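The compounds below may be only part of what the source reports. "The series", "measured", "known", "first", "only" and "open" are said of these compounds alone.

Working notes on the series. Compound 1 `CC(C)n1cc(S(=O)(=O)c2ccc(CNC(=O)N3Cc4ccncc4C3)cc2)cn1` gives 20 nM in an assay on isolated protein for inhibition of Nicotinamide phosphoribosyltransferase (Homo sapiens), read by mass spectrometry, with stated times of 15 min and 30 min; on this read-out lower numbers stand for stronger inhibition and higher numbers for weaker inhibition. Compound 2 `O=C(NCc1ccc(S(=O)(=O)C2CCCOC2)cc1)N1Cc2ccncc2C1` gives 44 nM in this assay, the step being a 2.2-fold higher number from compound 1 to compound 2 (0.34 log units; beyond the scatter). Compound 3 `O=C(NCc1ccc(S(=O)(=O)C2CCN(C3COC3)CC2)cc1)N1Cc2ccncc2C1` gives 31 nM in this assay; the steps are a 1.6-fold higher number from compound 1 to compound 3 (0.19 log units; within the scatter) and a 1.4-fold lower number from compound 2 to compound 3 (0.15 log units; within the scatter). On these numbers compound 3 stands second highest of the three, with compound 2 nearest and compound 1 furthest, both within the scatter.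

Compound 4 `O=C(NCc1ccc(S(=O)(=O)N2CCC(O)CC2)cc1)N1Cc2ccncc2C1` is not yet measured. The change from compound 3 is 4-hydroxypiperidin-1-yl in place of 1-(oxetan-3-yl)piperidin-4-yl on a sulfonyl sulfur. All three measured steps also exchange the group on the sulfonyl sulfur, and their sizes were modest at most: one beyond the scatter, two within it. A comparable small step is therefore expected in this assay for the move to compound 4, with no clear direction. Compound 4 is expected to give about 40 nM in this assay, with a range from 15 nM to 120 nM. This corresponds to an expected step of a 1.3-fold higher number from compound 3 to compound 4 (0.11 log units; within the scatter).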

Compound 4, half-maximal inhibitory concentration: 44 nM
For compound 4 the middle estimate is 1.1-fold (0.04 log units) below the measured one, and the stated range covers the measured number.
By their numbers in this assay, from the lowest: compounds 1, 3, 2 and 4 (each within the scatter of the next, the first and the last beyond it).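

In this assay, the change shows that the sulfonyl sulfur accepts a group bound through its ring nitrogen: 4-hydroxypiperidin-1-yl, with its hydrogen-bond donor, leaves the number within the scatter of both saturated groups (a 1.4-fold higher number from compound 3 to compound 4 (0.15 log units; within the scatter); no change at the digits printed from compound 2 to compound 4 (within the scatter)). Only the comparison with 1-isopropyl-1H-pyrazol-4-yl goes beyond the scatter (a 2.2-fold higher number from compound 1 to compound 4 (0.34 log units; beyond the scatter)), and it matches in size the step from that group to oxan-3-yl in compound 2. Nothing measured here accounts for these steps.

Going by these compounds, what the hydroxyl itself contributes stays open: a plain piperidin-1-yl or a 4-aminopiperidin-1-yl would separate it from the ring-nitrogen attachment. Also open, on these data alone, is whether another aromatic group on the sulfonyl sulfur, such as pyridin-3-yl, would give a number like that of compound 1.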